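This account rests on a few compounds, and the source may have more. Where it says the series, first, only, none or still open, it means among the compounds named here.

Measured in a functional assay on BXPC-3 cells (Homo sapiens) for antiproliferative activity, read by MTT assay, with a stated time of 24 h; a lower number here means a stronger inhibitor, a higher number a weaker inhibitor:
- Compound 1 `CCn1c(C(=O)N[C@H](CO)CCCO)ccc1C(CC)(CC)c1ccc(OCS(=O)(=O)c2ccccc2)c(C)c1`: > 50000 nM, a limit of the assay
- Compound 2 `CCn1c(C(=O)N[C@H](C)C(=O)O)ccc1C(CC)(CC)c1ccc(OCS(=O)(=O)c2ccccc2)c(C)c1`: 20100 nM
- Compound 3 `CCn1c(C(=O)N[C@@H](C(=O)O)C(C)C)ccc1C(CC)(CC)c1ccc(OCS(=O)(=O)c2ccccc2)c(C)c1`: 13900 nM

Compound 3 stands within the scatter of compound 2, as a 1.4-fold lower number from compound 2 to compound 3 (0.16 log units; within the scatter) shows. Among the compounds with values here, these are the only two numeric values in the set, since the entry for compound 1 is a limit (the limit of > 50000 nM in this assay, at which 1 of the 3 values shown sits).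

The next step leads to compound 4 `CCn1c(C(=O)NCCC(=O)O)ccc1C(CC)(CC)c1ccc(OCS(=O)(=O)c2ccccc2)c(C)c1`, which is still to be measured in this assay. The change is 2-carboxyethyl in place of 1-carboxy-2-methylpropyl on an amide-type nitrogen.

The closest guide is the exchange of isopropyl and methyl between the two carboxy-bearing compounds, a 1.4-fold lower number from compound 2 to compound 3 (0.16 log units; within the scatter). The two larger measured steps, an at least 2.4-fold lower number from compound 1 to compound 2 (0.39 log units; beyond the scatter) and an at least 3.5-fold lower number from compound 1 to compound 3 (0.55 log units; beyond the scatter), both start from a limit and give minimum sizes only. They involve compound 1, which has no carboxy group, whereas compound 4 keeps one. Within the data shown here, no measured compound carries the 2-carboxyethyl group, so the range is kept wide, and a limit reading cannot be excluded.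

No step beyond the scatter is expected. The estimate means a 1.4-fold higher number from compound 3 to compound 4 (0.14 log units; within the scatter), which is expected to be small and upward if it appears at all. Compound 4 is estimated at 19000 nM, with an expected range of 9000 nM to 42000 nM.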

Compound 4, half-maximal inhibitory concentration: > 50000 nM
Compound 4: only a limit was reported; the forecaster's own chance of this, stated with the estimate: 15%; at least 2.6-fold (0.42 log units) between middle value and limit.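

With the carboxy group kept, the change to 2-carboxyethyl on the amide-type nitrogen still moves the number in this assay: an at least 3.5-fold higher number from compound 3 to compound 4 (0.55 log units; beyond the scatter), and an at least 2.4-fold higher number from compound 2 to compound 4 (0.39 log units; beyond the scatter), both minimum sizes since the entry for compound 4 is a limit of the assay. The second of these steps is the closer comparison, since 1-carboxyethyl and 2-carboxyethyl differ only in where the carboxy group stands on the chain, and that step is printed beyond the scatter, whereas the exchange of methyl for isopropyl stays within it, at a 1.4-fold lower number from compound 2 to compound 3 (0.16 log units; within the scatter). A carboxy group alone therefore does not keep a reading inside the assay range, as compound 4, which carries one, now shares a limit with compound 1, which does not: the limit of > 50000 nM in this assay, at which 2 of the 4 values shown sit.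

Going by these compounds, the step between compound 1 and compound 4 cannot be read, as both entries are limits, and how far compound 4 lies past its limit stays open. Also open, on these data alone, is whether a methyl ester, a primary amide or an amine in place of the carboxy group on the 1-carboxyethyl chain would give a reading of the same order.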